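The source may report more compounds than this note shows. Statements on the series, on what has been measured and on what is new or still open speak of the compounds shown alone.

Working notes on the series. Three compounds share one core and differ only in the aryl group on the carbon with a double bond to nitrogen. Compound 1 `COc1ccc(OC)c(/C=N/NC(=O)Nc2ccc(Oc3ccnc(-c4nncn4CCN(C)C)c3)c(F)c2)c1` gives 1950 nM in a functional assay on A549 cells (Homo sapiens) for cytotoxicity, read by MTT assay, with a stated time of 72 h; on this read-out higher numbers stand for weaker inhibition and lower numbers for stronger inhibition. Compound 2 `CN(C)CCn1cnnc1-c1cc(Oc2ccc(NC(=O)N/N=C/c3ccc(F)cc3Cl)cc2F)ccn1` gives 1120 nM in this assay, the lowest of the three numbers, though the gap to compound 1 is within the scatter, so no order between those two is claimed. Compound 3 `COc1ccc(/C=N/NC(=O)Nc2ccc(Oc3ccnc(-c4nncn4CCN(C)C)c3)c(F)c2)c(OC)c1OC` gives 6680 nM in this assay.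

The measured steps at this position are a 1.7-fold lower number from compound 1 to compound 2 (0.24 log units; within the scatter), a 3.4-fold higher number from compound 1 to compound 3 (0.53 log units; beyond the scatter) and a 6.0-fold higher number from compound 2 to compound 3 (0.78 log units; beyond the scatter). Both steps that swap an oxygen-bearing aryl group for or against the halogenated one move the number in the same sense: away from the 2-chloro-4-fluorophenyl the number rises.

Compound 4 `CN(C)CCn1cnnc1-c1cc(Oc2ccc(NC(=O)N/N=C/c3ccc(O)cc3O)cc2F)ccn1` is not yet measured. It differs from compound 2 as follows: 2,4-dihydroxyphenyl in place of 2-chloro-4-fluorophenyl on a carbon with a double bond to nitrogen. The change leaves compound 2 and again removes the 2-chloro-4-fluorophenyl for an oxygen-bearing ring, so a modest rise in the number is expected, in the direction seen in the step from compound 2 to compound 3, though smaller in scale, since that step a 6.0-fold higher number from compound 2 to compound 3 (0.78 log units; beyond the scatter) concerned a different entering group. The expected step is a 2.2-fold higher number from compound 2 to compound 4 (0.35 log units; beyond the scatter). Compound 4 is therefore estimated at 2500 nM in this assay, with a range of 900 nM to 7000 nM.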

Compound 4, half-maximal inhibitory concentration: 12700 nM
Compound 4: middle estimate off by 5.1-fold (0.71 log units), on the low side; the measured number lies above the stated range.
By their numbers in this assay, from the lowest: compounds 2 and 1 (each within the scatter of the next); then compounds 3 and 4 (each within the scatter of the next).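

In this assay, the 2,4-dihydroxyphenyl group gives the largest step yet seen at this position, an 11-fold higher number from compound 2 to compound 4 (1.05 log units; beyond the scatter), and the comparison with the 2,5-dimethoxyphenyl group runs the same way, a 6.5-fold higher number from compound 1 to compound 4 (0.81 log units; beyond the scatter). Against the 2,3,4-trimethoxyphenyl group the change gives a 1.9-fold higher number from compound 3 to compound 4 (0.28 log units; within the scatter), so this read-out does not separate these two rings, and both stand apart from the rings of compound 1 and compound 2. No evidence is available that accounts for these steps.

Oxygen on the ring does not by itself set the number, as compound 1 goes against such a pattern and stays within the scatter of compound 2. The compounds shown leave open how a ring carrying a single hydroxyl, a single chlorine, an amine or a carboxylic acid would read here.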